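This account rests on a few compounds, and the source may have more. Where it says the series, first, only, none or still open, it means among the compounds named here.

Measured compounds, in a functional assay on NCI-H1975 cells (Homo sapiens) for antiproliferative activity, read by MTT assay, with a stated time of 72 h; on this read-out lower numbers stand for stronger inhibition and higher numbers for weaker inhibition:

Compound 1 `COc1cc2ncnc(Nc3ccc(F)c(Cl)c3)c2cc1OCCCCC(=O)Nc1ccc(S(N)(=O)=O)cc1` gives 35600 nM.
Compound 2 `COc1cc2ncnc(Nc3cccc(C)c3)c2cc1OCCCCC(=O)Nc1ccc(S(N)(=O)=O)cc1` gives 32100 nM.
Compound 3 `COc1cc2ncnc(Nc3cc(F)c(F)c(F)c3)c2cc1OCCCCC(=O)Nc1ccc(S(N)(=O)=O)cc1` gives 20000 nM.

All three share one core and differ only in the aromatic group carried on a nitrogen on an aromatic ring. Compound 3 stands within the usual scatter of both of its neighbours: the step of a 1.8-fold lower number from compound 1 to compound 3 (0.25 log units; within the scatter) and the step of a 1.6-fold lower number from compound 2 to compound 3 (0.21 log units; within the scatter) are each too small to count as a real difference, and the same holds for a 1.1-fold lower number from compound 1 to compound 2 (0.04 log units; within the scatter). On the numbers shown, none of the three exchanges of this aromatic group moved the result beyond what repeated measurement would give.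

Compound 4 `COc1cc2ncnc(Nc3ccc(C(F)(F)F)cc3)c2cc1OCCCCC(=O)Nc1ccc(S(N)(=O)=O)cc1` continues that series: 4-(trifluoromethyl)phenyl in place of 3,4,5-trifluorophenyl on a nitrogen on an aromatic ring. The three measured steps all bear on it, since each also exchanged this same group, and each stayed within the scatter. For the measured compounds named here, no measured pair shows what a trifluoromethyl group at this position does, so the expectation rests only on the observation that the group has so far been tolerant of change.

Compound 4 is therefore expected to fall near compound 3, a step of a 1.3-fold higher number from compound 3 to compound 4 (0.10 log units; within the scatter), with no change beyond the scatter. The estimate for compound 4 in this assay is 25000 nM, with a range from 10000 nM to 60000 nM.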

Compound 4, half-maximal inhibitory concentration: 12000 nM
The estimate for compound 4 lay 2.1-fold (0.32 log units) above the measured number; the range from low to high includes it.
By their numbers in this assay, from the lowest: compounds 4, 3, 2 and 1 (each within the scatter of the next, the first and the last beyond it).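

In this assay, this position now shows its first steps beyond the scatter, both modest: a 2.7-fold lower number from compound 2 to compound 4 (0.43 log units; beyond the scatter) and a 3.0-fold lower number from compound 1 to compound 4 (0.47 log units; beyond the scatter). Every earlier exchange of the aromatic group on this nitrogen had stayed within the scatter, so the group is less indifferent to change than those compounds suggested. The closest comparison is less clear, however: a 1.7-fold lower number from compound 3 to compound 4 (0.22 log units; within the scatter) stays within the scatter, so 4-(trifluoromethyl)phenyl can be told apart from 3-methylphenyl and 3-chloro-4-fluorophenyl, but not from 3,4,5-trifluorophenyl. No measurement here gives a reason for these steps.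

Going by these compounds, all four compounds carry a phenyl ring bearing only methyl, chlorine, fluorine or trifluoromethyl on this nitrogen, so it remains open how a phenyl ring carrying an amine or a carboxylic acid would behave. On these data alone, every compound also keeps the same chain and amide end, so it is equally open whether a longer chain would change the numbers in this assay more than any exchange at this position has.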